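From Hydroxy to Acetoxy on Compound 1

The source may report more compounds than this note shows. Statements on the series, on what has been measured and on what is new or still open speak of the compounds shown alone.

For the measured compounds named here, in a functional assay on Hep 3B2 cells (Homo sapiens) for cytotoxicity, read by XTT assay (a higher number here means a weaker inhibitor, a lower number a stronger inhibitor), compound 1 (`C/C(=C\[C@@H](O)C/C(C)=C/CCc1ccoc1)CC[C@@H](O)[C@]1(C)CCC(=O)O1`) gives 6400 nM, the only actual number so far. Compound 2 (`C/C(=C\[C@@H](O)C/C(C)=C/CCCC(=O)CO)CC[C@@H](O)[C@]1(C)CCC(=O)O1`) gives > 20000 nM, which is a limit. Compound 3 (`CC(=O)O[C@H](CC/C(C)=C/[C@@H](O)C/C(C)=C/CCc1ccoc1)[C@]1(C)CCC(=O)O1`) differs from compound 1 by acetyl in place of hydrogen on an oxygen on a saturated carbon. Going by the values given here, the only measured step, an at least 3.1-fold higher number from compound 1 to compound 2 (0.49 log units; beyond the scatter), exchanges furan-3-yl for ((hydroxymethyl)carbonyl)methyl and leaves the hydroxy group untouched, so it is a weak guide here. The expected step, a 1.3-fold lower number from compound 1 to compound 3 (0.11 log units; within the scatter), is therefore estimated to stay within the scatter in this assay, with no clear direction. Compound 3 is estimated at 5000 nM, with an expected range of 1500 nM to 18000 nM.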

Compound 3, half-maximal inhibitory concentration: 1100 nM
Estimate against measurement, compound 3: 4.5-fold (0.66 log units) above, and the stated range ends above it.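

In this assay acetoxy in place of hydroxy on this saturated carbon gives a 5.8-fold lower number from compound 1 to compound 3 (0.76 log units; beyond the scatter) and so moves the number down, which the earlier step, made at the other end of the chain, could not show. This oxygen therefore accepts an acetyl group without loss of activity, and the change improves on compound 1 beyond the scatter. Nothing shown here accounts for the size of this step.

From the compounds shown here alone, it remains open whether a longer acyl chain such as butanoyl, or a methyl ether, would act like acetyl at this oxygen. Acetyl on the other hydroxy group of the chain is equally open.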